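The source may report more compounds than this note shows. Statements on the series, on what has been measured and on what is new or still open speak of the compounds shown alone.

Working notes on the series

Three compounds of the shared core have numbers in a functional assay on THP-1 cells (Homo sapiens) for antiproliferative activity, tested at 20 uM; a higher number here means a stronger effect of the compound at the concentration tested, a lower number a weaker effect. Compound 1 `CC(=O)Oc1ccc(CONC(=O)c2ccc(CS(=O)(=O)Nc3ccc4cc(C)c(=O)n(C)c4c3)cc2)cc1` gives 1% in this assay. Compound 2 `Cc1cc2cc(NS(=O)(=O)c3cc(C(=O)NO)ccc3Cl)ccc2n(C)c1=O` gives 8%. Compound 3 `COC(=O)c1ccc(CS(=O)(=O)Nc2ccc3c(c2)cc(C)c(=O)n3C)cc1` gives 9%, which is the highest of the three numbers, though the gaps to compound 2 and to compound 1 both lie within the usual scatter, so no order among the three can be drawn from them. All three sit at the low end of the read-out at the concentration tested.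

Compound 4 `Cc1cc2cc(NS(=O)(=O)Cc3ccc(C(=O)NO)cc3)ccc2n(C)c1=O` has not been measured. It differs from compound 3 at one place: hydroxyamino in place of methoxy on a carbonyl carbon. Compound 2 already carries a hydroxycarbamoyl group and gives a number in the same low band as compound 3, so there is no measured ground for a large movement in either direction. The change from compound 3 to compound 4 is therefore expected to give a step of a number 6 percentage points higher from compound 3 to compound 4 (within the scatter), small and not clearly beyond the scatter. Compound 4 is expected to give about 15% in this assay, with a range from 0% to 40%.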

Compound 4, a percentage reported as inhibition, at one concentration (the size of the read-out at that concentration, not a potency): 8%
Estimate against measurement, compound 4: 7 percentage points above, within the range that was stated.
By their numbers in this assay, from the lowest: compounds 1, 2, 4 and 3 (each within the scatter of the next).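

In this assay, within the data shown here, hydroxyamino in place of methoxy on a carbonyl carbon gives a number 1 percentage points lower from compound 3 to compound 4 (within the scatter) and this is the first direct reading of this change on an otherwise identical structure. Compound 2 also carries a hydroxycarbamoyl group but differs from compound 3 in more than one place, so it could not isolate the exchange. At the concentration tested, the methoxycarbonyl and hydroxycarbamoyl forms cannot be told apart, and nothing measured here offers an explanation for this result.

A carboxylic acid or a primary amide on this carbonyl carbon lies outside the compounds shown, so it remains open whether any group at this place gives a number outside the low band. As far as these compounds go, it also remains open whether the two forms would still match at another concentration.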